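Removing the aryl methyl of compound 2

This account rests on a few compounds, and the source may have more. Where it says the series, first, only, none or still open, it means among the compounds named here.

Compound 2 `CC(=O)Nc1cc(-c2ccc(OC[C@@H](N)CC(C)C)c(C)c2)ccn1` gives 0.4 nM in an assay on isolated protein for inhibition of AP2-associated protein kinase 1 (Homo sapiens), with a stated time of 3 h, in the presence of a further agent that is not named here (on this read-out lower numbers stand for stronger inhibition and higher numbers for weaker inhibition), the lowest of the two numbers in hand. Compound 1 `COC(=O)Nc1cc(-c2ccc(OC[C@@](C)(N)CC(C)C)c(F)c2)ccn1` gives 1.1 nM in this assay, a higher number than compound 2 by a margin beyond the usual scatter. Among the compounds with values here, the two structures differ in more than one place, so this pair isolates no single change and no step between measured compounds is available.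

Compound 3 `CC(=O)Nc1cc(-c2ccc(OC[C@@H](N)CC(C)C)cc2)ccn1` has not yet been measured. It differs from compound 2 in one place only: hydrogen in place of methyl on an aromatic carbon, a hydrogen in place of methyl on an aromatic carbon, ortho to the (2-amino-4-methylpentyl)oxy group. Within the data shown here, no measured pair shows the effect of this change, so the expectation rests on compound 2 alone. With the rest of compound 2 kept intact, the step from compound 2 to compound 3 in this assay is expected to be small, most likely toward a somewhat higher number, and it may well stay within the scatter. The expected step is a 2.0-fold higher number from compound 2 to compound 3 (0.30 log units; within the scatter). Compound 3 is estimated at 0.8 nM, with a range from 0.3 nM to 2.5 nM.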

Compound 3, half-maximal inhibitory concentration: 4.6 nM
For compound 3 the middle estimate is 5.8-fold (0.76 log units) below the measured one, outside the stated range (above it).
By their numbers in this assay, from the lowest: compound 2; then compound 1; then compound 3.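

In this assay, hydrogen in place of methyl on this aromatic carbon, ortho to the (2-amino-4-methylpentyl)oxy group, gives a 12-fold higher number from compound 2 to compound 3 (1.06 log units; beyond the scatter), a large step beyond the scatter. Within the data shown here, this is the first one-place comparison, and it shows that this position is not indifferent: the loss of 1 heavy atom, a group with 0 hydrogen-bond donors and 0 hydrogen-bond acceptors, is enough to move the read-out markedly when the rest of compound 2 stays intact. The compounds in hand offer no measurement that accounts for the size of this step.

Going by these compounds, it remains open whether the low number of compound 2 at 0.4 nM depends on methyl itself or would also hold with a chlorine atom, a methoxy group or an ethyl group on the same carbon. Also open, on these data alone, is whether the step carries over to the methyl carbamate with the added methyl on the amine-bearing carbon seen in compound 1, which differs from compound 2 in more than one place and has no matching partner with hydrogen on this carbon.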